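This account rests on a few compounds, and the source may have more. Where it says the series, first, only, none or still open, it means among the compounds named here.

Compound 3 `CCC(C)(C)Cc1c[nH]c(CCc2ccc(-c3ccccc3C(=O)O)cc2)n1` gives 101 nM in a functional assay on HEK293 cells for agonist activity at Bombesin receptor subtype-3 (Homo sapiens), read by luminescence and calcium flux, with a stated time of 10 min (on this read-out lower numbers stand for an effect already at smaller amounts and higher numbers for an effect only at larger amounts of compound), and shows the lowest of the three numbers, though compound 1 `CCC(C)(C)Cc1c[nH]c(CCc2ccc(-c3cccc(C)n3)cc2)n1` with 102 nM and compound 2 `CCC(C)(C)Cc1c[nH]c(CCc2ccc(-n3cccn3)cc2)n1` with 106 nM both lie within the scatter of it. Compound 4 `CCC(C)(C)Cc1c[nH]c(CCc2ccc(-c3ccc(F)cn3)cc2)n1` differs from compound 3 by 5-fluoropyridin-2-yl in place of 2-carboxyphenyl on an aromatic carbon. Within the data shown here, the steps that bear on this exchange at the same position are a 1.0-fold lower number from compound 1 to compound 3 (0.00 log units; within the scatter) and a 1.0-fold lower number from compound 2 to compound 3 (0.02 log units; within the scatter), so three quite different groups on this aromatic carbon gave numbers that cannot be told apart. Returning a pyridin-2-yl group bearing fluorine in place of the methyl of compound 1 is therefore expected to give no step beyond the scatter, a 1.0-fold lower number from compound 3 to compound 4 (0.00 log units; within the scatter). For compound 4 the estimate is 100 nM, with a range from 50 nM to 200 nM.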

Compound 4, half-maximal effective concentration: 97 nM
The estimate for compound 4 lay 1.0-fold (0.01 log units) above the measured number; measured number inside the range.
By their numbers in this assay, from the lowest: compounds 4, 3, 1 and 2 (each within the scatter of the next).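

Placing 5-fluoropyridin-2-yl on this aromatic carbon gives a 1.0-fold lower number from compound 3 to compound 4 (0.02 log units; within the scatter), a 1.1-fold lower number from compound 2 to compound 4 (0.04 log units; within the scatter) and a 1.1-fold lower number from compound 1 to compound 4 (0.02 log units; within the scatter), so in this assay a fourth group cannot be told apart from the other three. The exchange for 2-carboxyphenyl also gives up its hydrogen-bond donor, and the number stays within the scatter. No measurement at hand explains why these groups give such similar numbers.

From the compounds shown here alone, what an amine or a longer chain on this carbon would give stays open, as does whether changes elsewhere on the shared core would move the number further.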